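Demethylation at the aryl oxygen in a hydrazone series

The source may report more compounds than this note shows. Statements on the series, on what has been measured and on what is new or still open speak of the compounds shown alone.

In a physicochemical assay on cells (Homo sapiens), with a stated time of 18 h, tested at 10 uM (a lower number here means a stronger effect, a higher number a weaker effect of the compound at the concentration tested), compound 2 `COc1cc(/C=N/NC(=O)c2ccncc2)cc(OC)c1OC` gives 94%, and compound 1 `COc1cc(/C=N/NC(=O)c2ccncc2)cc(OC)c1O` gives 7%. Within the data shown here, the one change between them is hydrogen in place of methyl on an oxygen on an aromatic ring, and it made a step of a number 87 percentage points lower from compound 2 to compound 1 (beyond the scatter). Compound 3 `COc1cc(/C=N/NC(=O)OCc2ccccc2)ccc1O` gives 36% in this assay, so its number sits between the other two, lower than that of compound 2 and higher than that of compound 1. The difference between the core of compound 3 and the core of compound 2 is not broken down here.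

Compound 4 `O=C(N/N=C/c1ccc(O)c(O)c1)OCc1ccccc1` has not yet been measured. It differs from compound 3 by hydrogen in place of methyl on an oxygen on an aromatic ring, the same change that separates compound 2 from compound 1, and this change occurs twice among the compounds shown. The expected step of a number 24 percentage points lower from compound 3 to compound 4 (beyond the scatter) is taken as downward but smaller than the earlier one, because compound 3 already starts from 36%, leaving less room to fall. This expectation rests on a single earlier example of the change, on a different core.

Compound 4 is estimated at 12%, with a range from 3% to 28%.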

Compound 4, a percentage reported as activity, at one concentration (the size of the read-out at that concentration, not a potency): 6%
Beside the measured number, compound 4's estimate is 6 percentage points above it; the measured number falls inside the stated range.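

In this assay, methoxy to hydroxy gives a number 30 percentage points lower from compound 3 to compound 4 (beyond the scatter) and, on the other core, a number 87 percentage points lower from compound 2 to compound 1 (beyond the scatter) as well, so the downward direction of the change holds on both cores shown. This rests on one pair per core: it does not show that the size of the step carries from one core to another, or that the direction would hold on a third core. No measurement shown here bears on the reason for the effect of this change.

From the compounds shown here alone, it remains open whether a group other than hydroxy at that place, such as an amine, an ethoxy group or a longer chain on the oxygen, would give a similarly low number. The cores of compound 1 and compound 4 differ in more than one place, so what each part of those cores contributes also remains unresolved.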